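Series notes: swapping the aryl ether of compound 1

This account rests on a few compounds, and the source may have more. Where it says the series, first, only, none or still open, it means among the compounds named here.

All numbers come from a functional assay on CAKI-1 cells (Homo sapiens) for inhibition, read by sulforhodamine B assay, with a stated time of 48 h; a higher number here means a weaker inhibitor of growth, a lower number a stronger inhibitor of growth.

compound 1 `Nc1cc(N)c2nc(-c3ccccc3)c(Oc3ccc(Cl)c(Cl)c3)nc2c1`: 15800 nM
compound 2 `CCOC(=O)[C@H](CCC(=O)O)NC(=O)c1ccc(Sc2nc3cc(N)cc(N)c3nc2-c2ccccc2)cc1`: 79400 nM
compound 3 `COc1cc(CNc2nc3cc(N)cc(N)c3nc2-c2ccccc2)cc(OC)c1OC`: 1910 nM

Compound 1 holds the second highest of the three numbers in this assay. Compound 2, which carries an aryl thioether on the shared core, gives a higher number than compound 1, and the gap lies beyond the scatter. Compound 3, which carries a substituted benzylamine at the same place, gives a lower number than compound 1, again beyond the scatter. Within the data shown here, no pair of these three differs in only one place, so no single step within the measured set can be isolated.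

Compound 4 `Nc1cc(N)c2nc(-c3ccccc3)c(NCc3ccc(F)cc3)nc2c1` is not yet measured. It differs from compound 1 by (4-fluorobenzyl)amino in place of 3,4-dichlorophenoxy on an aromatic carbon. Among the measured compounds, the only one with a benzylamine at this place is compound 3, which gives 1910 nM, and that is the nearest guide available. On that basis the expected step from compound 1 to compound 4 is downward and beyond the scatter, at about a 4.0-fold lower number from compound 1 to compound 4 (0.60 log units; beyond the scatter). For compound 4 the estimate in this assay is 4000 nM, with a range from 1000 nM to 16000 nM; the range is wide because only compound 3, at 1910 nM, supports the guess, and its benzyl group is substituted differently.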

Compound 4, concentration for 50% growth inhibition: 15100 nM
Beside the measured number, compound 4's estimate is 3.8-fold (0.58 log units) below it; low and high end bracket the measured number.
By their numbers in this assay, from the lowest: compound 3; then compounds 4 and 1 (each within the scatter of the next); then compound 2.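

In this assay, the exchange of 3,4-dichlorophenoxy for (4-fluorobenzyl)amino on the aromatic carbon next to the ring nitrogen gives a 1.0-fold lower number from compound 1 to compound 4 (0.02 log units; within the scatter), so this change, which brings in a hydrogen-bond donor at an equal heavy-atom count, leaves the two compounds indistinguishable in this assay. The position therefore tolerates this oxygen-linked and this nitrogen-linked aryl group with no measurable separation between them. A benzylamine at this place does not by itself go with the lowest number in the set: compound 3 gives 1910 nM and compound 4 gives 15100 nM, so the two benzyl groups, three methoxy groups on one and a fluorine on the other, separate two compounds that share the nitrogen link. No measurement at hand bears on the reason for these numbers.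

Open, as far as these compounds go, is which of the methoxy groups of compound 3 goes with its lower number, and whether an unsubstituted benzylamine or a single 4-methoxybenzylamine would fall nearer compound 3 or compound 4. A 3,4-dichlorobenzylamine at this place would also set the dichloro pattern directly on the nitrogen link.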